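Ethyl for methyl on the amine nitrogen of compound 1

This account rests on a few compounds, and the source may have more. Where it says the series, first, only, none or still open, it means among the compounds named here.

Compound 1 `CN(CCC(=O)[O-])[N+](C)(C)C` gives the lowest number of the two measured in an assay for inhibition of gamma-butyrobetaine dioxygenase (Homo sapiens), read by HPLC, with stated times of 15 min and 30 min (a lower number here means a stronger inhibitor, a higher number a weaker inhibitor), with compound 1 at 90 nM; the nearest is compound 2 `CC[N+](C)(C)N(C)CCC(=O)[O-]`, which in this assay gives 7200 nM. Compound 3 `CCN(CCC(=O)[O-])[N+](C)(C)C` differs from compound 1 by methyl in place of hydrogen on a saturated chain carbon bound to an amine nitrogen. Within the data shown here, the same kind of change is seen in the one measured step, an 80-fold higher number from compound 1 to compound 2 (1.90 log units; beyond the scatter), so a large rise is expected in this assay, though only one such step supports it. For compound 3 the estimate is 2000 nM, range 300 nM to 15000 nM, meaning an expected step of a 22-fold higher number from compound 1 to compound 3 (1.35 log units; beyond the scatter).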

Compound 3, half-maximal inhibitory concentration: 2800 nM
The estimate for compound 3 lay 1.4-fold (0.15 log units) below the measured number; low and high end bracket the measured number.
By their numbers in this assay, from the lowest: compound 1; then compound 3; then compound 2.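

In this assay the change from methyl to ethyl gives a second large rise, a 31-fold higher number from compound 1 to compound 3 (1.49 log units; beyond the scatter), at a different site of the core of compound 1 from the one in an 80-fold higher number from compound 1 to compound 2 (1.90 log units; beyond the scatter). The loss from this single added carbon is therefore not confined to one site in the series. Nothing available explains the rise at either site.

Still open, as far as these compounds go, is how a longer chain such as propyl, or a hydrogen in place of this methyl, would read at this place. Also open, from the compounds shown here alone, is whether a ring-closed amine would fare any better.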